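The source may hold more compounds than are shown below. What is called first, only, known or untested is meant among the compounds shown, and "the series" means these compounds.

Of the compounds shown here, three have so far been measured in an assay on BTI cells for inhibition of Amine oxidase [flavin-containing] B (Homo sapiens), read by fluorescence, with stated times of 30 min and 1 h, tested at 1 uM; a higher number here means more inhibition at the concentration tested (going by the name of the read-out), a lower number less inhibition. Compound 1, `C#CCNC1CCc2c(OCCCN3CCN(c4cccc5c4ccn5Cc4cccc(Cl)c4)CC3)cccc21`, gives 31%. Compound 2, `C#CCNC1CCc2c(OCCCCCN3CCN(c4cccc5c4ccn5Cc4cccc(Cl)c4)CC3)cccc21`, gives 80% in this assay. Compound 3, `C[C@H](NCc1ccc(OCCCCN2CCN(c3cccc4c3ccn4Cc3cccc(Cl)c3)CC2)cc1)C(N)=O`, gives 24% in this assay. Of these three numbers, compound 3 stands lowest; its nearest neighbour is compound 1, whose number lies within the usual scatter of it, so no order between compound 3 and compound 1 can be claimed, while compound 2 lies furthest away, higher by an amount beyond the scatter.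

Compound 4, `C[C@H](NCc1ccc(OCCCCN2CCN(c3cccc4c3ccn4S(=O)(=O)c3ccccc3)CC2)cc1)C(N)=O`, has not yet been measured in this assay. It differs from compound 3 in one place: phenylsulfonyl in place of 3-chlorobenzyl on an aromatic nitrogen. Among the compounds with values here, no pair of measured compounds shares a single-point step, so no measured step covers this change. Given that compound 3 gives 24% in this assay, the expected step is small, a number 6 percentage points lower from compound 3 to compound 4 (within the scatter), most likely within the scatter and leaning if anything toward less inhibition. Compound 4 is therefore estimated to give 18% in this assay, with a range from 0% to 45%.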

Compound 4, a percentage reported as inhibition, at one concentration (the size of the read-out at that concentration, not a potency): 20%
For compound 4 the middle estimate is 2 percentage points below the measured one, within the range that was stated.
By their numbers in this assay, from the lowest: compounds 4, 3 and 1 (each within the scatter of the next, the first and the last beyond it); then compound 2.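

In this assay, placing phenylsulfonyl in place of 3-chlorobenzyl on an aromatic nitrogen gives a number 4 percentage points lower from compound 3 to compound 4 (within the scatter) and provides the first single-point step among these compounds, so the two groups cannot be told apart at this position. The entering group carries 2 hydrogen-bond acceptors and 2 double bonds outside aromatic rings, which the leaving group lacks, and both groups hold one six-membered aromatic ring of carbon only, yet no difference in inhibition can be claimed. Nothing on hand gives a reason for this result.

From the compounds shown here alone, whether a plain hydrogen, a methyl or a benzoyl group on the same nitrogen would also leave the number unresolved from that of compound 3 stays open. Also open, going by these compounds, is whether phenylsulfonyl would give a similar result on the core of compound 2.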